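A few compounds are considered here, and "the series" means these few. Any claim that something is new, unique, unknown or untested is made for them only; others in the source may bear on it.

The series was examined in an assay for inhibition of histone deacetylase 8 (Homo sapiens), read by fluorescence, with stated times of 15 min and 60 min; a lower number here means a stronger inhibitor, a higher number a weaker inhibitor. Compound 1 `CC(=O)N1C(NCc2ccc(C(=O)Nc3ccccc3N)cc2)=NC(=O)C1Cc1ccccc1` gives 22700 nM in this assay. Compound 2 `CC(=O)N1C(NCc2ccc(C(=O)Nc3ccccc3N)cc2)=NC(=O)C1Cc1c[nH]c2ccccc12` gives 24300 nM, and the change from compound 1 to compound 2, 1H-indol-3-yl in place of phenyl on a saturated chain carbon bound to a saturated ring carbon, produced a 1.1-fold higher number from compound 1 to compound 2 (0.03 log units; within the scatter), so the two values sit within the scatter of each other. Compound 3 `CC(C)(C)[Si](C)(C)OCc1ccc(NC(=O)c2ccc(CNc3nccc(-c4cccnc4)n3)cc2)c(N)c1` returned only a limit, > 20000 nM, and not a number. Thus compound 1 and compound 2 are the only two compounds with numbers, and one further value is a limit, (the limit of > 20000 nM in this assay, at which 1 of the 3 values shown sits).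

Compound 4 `Nc1ccccc1NC(=O)c1ccc(CNC2=NC(=O)C(Cc3ccccc3)N2)cc1` differs from compound 1 by a single change: hydrogen in place of acetyl on an amine nitrogen in a ring. Among the compounds with values here, no measured step touches the acetyl on the amine nitrogen in the ring; the one measured step concerns the group on the saturated chain carbon and was within the scatter. There is therefore no measured basis for a step in either direction, and compound 4 is expected to sit near compound 1 in this assay, with the step from compound 1 to compound 4 estimated as a 1.0-fold lower number from compound 1 to compound 4 (0.01 log units; within the scatter). Compound 4 is expected to give about 22000 nM, with a likely range from 7000 nM to 70000 nM.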

Compound 4, half-maximal inhibitory concentration: 13000 nM
Estimate against measurement, compound 4: 1.7-fold (0.23 log units) above; the measured number falls inside the stated range.
By their numbers in this assay, from the lowest: compounds 4, 1 and 2 (each within the scatter of the next).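

Within the data shown here, with a 1.7-fold lower number from compound 1 to compound 4 (0.24 log units; within the scatter), the piece shows for the first time what happens at the amine nitrogen in the ring, a place the earlier step did not touch: loss of the acetyl, with hydrogen entering, does not carry the number beyond the usual scatter in this assay. So this assay does not separate the acetyl compound from the compound with hydrogen at this nitrogen, and both single changes now read on compound 1, this one and the one at the saturated chain carbon, stay within the scatter. No measured property in the data bears on this result, so nothing can be said of why the acetyl can be lost without a step beyond the scatter.

The compounds shown leave open whether a methyl, a longer acyl chain or a group carrying a carboxylic acid on this ring nitrogen would stay within the scatter as well. They also leave open how the 1H-indol-3-yl group would read with hydrogen on this nitrogen, and whether any change to the shared core would move the number further.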